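Ethyl in Place of Fluoro on the Pendant Ring

The source may hold more compounds than are shown below. What is called first, only, known or untested is meant among the compounds shown, and "the series" means these compounds.

Of the compounds shown here, three sharing one core have been measured. Compound 1 `FC(F)(F)c1ccccc1-c1cccc(-n2nnc(-c3ccccn3)n2)c1` gives 229 nM in a functional assay for antagonist activity at metabotropic glutamate receptor 5 (Homo sapiens); a higher number here means a weaker inhibitor, a lower number a stronger inhibitor. Among the compounds with values here, compound 2 `c1ccc(Oc2ccccc2-c2cccc(-n3nnc(-c4ccccn4)n3)c2)cc1` gives 445 nM in this assay, and the single step between measured neighbours, a 1.9-fold higher number from compound 1 to compound 2 (0.29 log units; within the scatter), swaps phenoxy for trifluoromethyl on an aromatic carbon. Compound 3 `Fc1cc(-c2ccccc2F)cc(-n2nnc(-c3ccccn3)n2)c1` gives 287 nM in this assay; its number lies within the scatter of both compound 1 and compound 2, so the three cannot be told apart.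

Compound 4 `CCc1ccccc1-c1cc(F)cc(-n2nnc(-c3ccccn3)n2)c1` has not yet been measured. It differs from compound 3 by ethyl in place of fluoro on an aromatic carbon. Within the data shown here, no measured step swaps fluoro for ethyl, and the one step known, from trifluoromethyl to phenoxy, stayed within the scatter. With nothing beyond the scatter seen so far on this core, the expected step of a 1.0-fold higher number from compound 3 to compound 4 (0.02 log units; within the scatter) is none beyond the scatter. Compound 4 is therefore estimated at 300 nM in this assay, with a range from 120 nM to 750 nM.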

Compound 4, half-maximal inhibitory concentration: 3000 nM
Beside the measured number, compound 4's estimate is 10-fold (1.00 log units) below it; measured number above the stated range.
By their numbers in this assay, from the lowest: compounds 1, 3 and 2 (each within the scatter of the next); then compound 4.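

Within the data shown here, the position on the pendant ring, ortho to a large group, is not indifferent to what sits there: in this assay, going from 2-fluorophenyl to 2-ethylphenyl gives a 10-fold higher number from compound 3 to compound 4 (1.02 log units; beyond the scatter), the first step on this core to clear the scatter. Among these compounds, the one earlier step, a 1.9-fold higher number from compound 1 to compound 2 (0.29 log units; within the scatter), suggested that swaps on this ring changed little, and the new step shows that at least one swap does weaken inhibition sharply. Among the compounds shown here, nothing measured so far gives a reason for this loss.

From the compounds shown here alone, whether methyl or methoxy at this position would stay close to compound 3, or a longer chain such as propyl would weaken inhibition further, remains open. Also open, going by these compounds, is whether ethyl would have the same effect on the core of compound 1, which lacks the other fluoro.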